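A few compounds are considered here, and "the series" means these few. Any claim that something is new, unique, unknown or untested is made for them only; others in the source may bear on it.

Working notes on a small set of ethers on a shared core, tested in an ADME assay on Huh-5-2 cells (Homo sapiens) for cytotoxicity, read by WST assay, with a stated time of 3 days; a lower number here means that less compound is tolerated, a higher number that more compound is tolerated. Compound 1 `O=c1c(OCc2ccccc2[N+](=O)[O-])c(-c2ccccc2)oc2cc(O)cc(O)c12` gives 51000 nM. Compound 2 `Cc1ccccc1COc1c(-c2ccccc2)oc2cc(O)cc(O)c2c1=O` gives 55000 nM; it differs from compound 1 by methyl in place of nitro on an aromatic carbon, and the step is a 1.1-fold higher number from compound 1 to compound 2 (0.03 log units; within the scatter). Compound 3 `O=c1c(OCc2cccc([N+](=O)[O-])c2)c(-c2ccccc2)oc2cc(O)cc(O)c12` gives 31000 nM; it differs from compound 1 by 3-nitrophenyl in place of 2-nitrophenyl on a saturated chain carbon bound to an oxygen on an aromatic ring, and the step is a 1.6-fold lower number from compound 1 to compound 3 (0.22 log units; within the scatter). Between the other pair the step is a 1.8-fold lower number from compound 2 to compound 3 (0.25 log units; within the scatter). All three values lie within the scatter of one another, so no order among them can be read.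

Compound 4 `Cc1cccc(COc2c(-c3ccccc3)oc3cc(O)cc(O)c3c2=O)c1` is not yet measured. It differs from compound 3 by methyl in place of nitro on an aromatic carbon. This is the same kind of change as that from compound 1 to compound 2, but the place differs: there the group sits ortho to a large group, here meta to a large group. Because a 1.1-fold higher number from compound 1 to compound 2 (0.03 log units; within the scatter) stayed within the scatter, the step of a 1.1-fold higher number from compound 3 to compound 4 (0.05 log units; within the scatter) is expected to be of similar size. This expectation rests on compound 3 at 31000 nM. Compound 4 is therefore estimated at 35000 nM, with a range from 18000 nM to 70000 nM.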

Compound 4, half-maximal cytotoxic concentration: 29000 nM
Estimate against measurement, compound 4: 1.2-fold (0.08 log units) above; measured number inside the range.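

In this assay the new step is a 1.1-fold lower number from compound 3 to compound 4 (0.03 log units; within the scatter), and the other two steps that reach it, a 1.9-fold lower number from compound 2 to compound 4 (0.28 log units; within the scatter) and a 1.8-fold lower number from compound 1 to compound 4 (0.25 log units; within the scatter), allow no order among these compounds either. Set beside the earlier step, methyl in place of nitro gives no readable difference between the two cores: the same change on two cores in this assay, a 1.1-fold higher number (0.03 log units; within the scatter) from compound 1 to compound 2 and a 1.1-fold lower number (0.03 log units; within the scatter) from compound 3 to compound 4, 1.2-fold (0.06 log units) apart, within the scatter of two such steps. Going by these compounds alone, this shows only that a step too small to read stays too small on both cores in this one assay; it does not show that a change of real size would carry from one core to the other, nor that the result would hold on a further core.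

The compounds shown leave open whether any group on the aromatic ring of the ether moves this read-out beyond the scatter, as every step among them lies within it. Also open, going by these compounds, is what an amine or a carboxylic acid in place of the methyl or nitro, or a longer chain in the ether, would give.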